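Sulfonyl aryl trimming in the sulfone series

The source may report more compounds than this note shows. Statements on the series, on what has been measured and on what is new or still open speak of the compounds shown alone.

Measured so far:
compound 1 `Cc1ccc2ncc(S(=O)(=O)c3ccc(Cl)c(Cl)c3)c(N3CCC(C)CC3)c2c1` — 82%
compound 2 `Cc1ccc(S(=O)(=O)c2cnc3ccc(C)cc3c2N2CCC(C)CC2)cc1` — 82%

In an assay on isolated protein for displacement of a labelled ligand from metabotropic glutamate receptor 5 (Homo sapiens), with a stated time of 60 min, tested at 1 uM (on this read-out lower numbers stand for less inhibition and higher numbers for more inhibition at the one concentration tested (going by the name of the read-out)), compound 1 gives 82% and compound 2 gives 82%. Going by the values given here, the one step so far, no change at the digits printed from compound 1 to compound 2 (within the scatter), is 4-methylphenyl in place of 3,4-dichlorophenyl on a sulfonyl sulfur, and it left the read-out unmoved within the scatter. Compound 2 therefore stands level with compound 1 at the digits shown; it is the nearest reference for the next compound.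

Compound 3 `Cc1ccc2ncc(S(=O)(=O)c3ccccc3)c(N3CCC(C)CC3)c2c1` is the next member. Its difference from compound 2 is hydrogen in place of methyl on an aromatic carbon. Cut one bond further out, it reads 4-methylphenyl to phenyl, so it again varies the aryl group on the sulfonyl sulfur. Among the compounds with values here, the only step that bears on it is no change at the digits printed from compound 1 to compound 2 (within the scatter), a far larger change of the same aryl group, which stayed within the scatter. On that basis compound 3 is expected to show no step beyond the scatter, a number 4 percentage points lower from compound 2 to compound 3 (within the scatter), in this assay. Compound 3 is thus estimated at 78%, with a range of 62% to 92%.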

Compound 3, a percentage reported as inhibition, at one concentration (the size of the read-out at that concentration, not a potency): 67%
Estimate against measurement, compound 3: 11 percentage points above; measured number inside the range.
By their numbers in this assay, from the lowest: compound 3; then compounds 1 and 2 (each within the scatter of the next).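

In this assay, the aryl group on the sulfonyl sulfur proves not to be indifferent: taking the methyl off 4-methylphenyl gives a number 15 percentage points lower from compound 2 to compound 3 (beyond the scatter), and phenyl in place of 3,4-dichlorophenyl gives a number 15 percentage points lower from compound 1 to compound 3 (beyond the scatter). The earlier step, no change at the digits printed from compound 1 to compound 2 (within the scatter), showed only that two substituted aryl groups read alike; the unsubstituted phenyl now shows that, across these compounds, the read-out holds with either substituted ring and drops beyond the scatter without one, and none of the compounds shown goes against this. Nothing available explains the drop, and the data give no reason for it.

The compounds shown leave open whether the read-out depends on the particular group or simply on having some group on that aromatic carbon, para to a large group, which a single chlorine, a methoxy or a trifluoromethyl group there would help to separate. They also leave open how these steps would look as potencies, since each read-out is the size of the inhibition at one concentration.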